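This account rests on a few compounds, and the source may have more. Where it says the series, first, only, none or still open, it means among the compounds named here.

All three measured compounds share one core and differ only in the aromatic group attached to the five-membered ring. In a functional assay on the whole organism for inhibition, with Mythimna separata as the target, with a stated time of 5 days (on this read-out lower numbers stand for an effect already at smaller amounts and higher numbers for an effect only at larger amounts of compound), compound 1 `CC(C)(C)n1ncc(OCc2nnc(-c3ccc(F)cc3)o2)c(Cl)c1=O` gives 5.2 ug/mL, compound 2 `CCc1ccc(-c2nnc(COc3cnn(C(C)(C)C)c(=O)c3Cl)o2)cc1` gives 14.5 ug/mL, and compound 3 `CC(C)(C)n1ncc(OCc2nnc(-c3ccc(Cl)cc3F)o2)c(Cl)c1=O` gives 10.4 ug/mL. Compound 3 thus holds the second highest number of the three: its nearest neighbour is compound 2, and the gap a 1.4-fold lower number from compound 2 to compound 3 (0.14 log units; within the scatter) is within the scatter; the larger gap, a 2.0-fold higher number from compound 1 to compound 3 (0.30 log units; within the scatter), also stays within the scatter.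

Compound 4 `CC(C)(C)n1ncc(OCc2nnc(-c3ccco3)o2)c(Cl)c1=O` differs from compound 3 in one place: furan-2-yl in place of 4-chloro-2-fluorophenyl on an aromatic carbon. Two measured steps exchange the aromatic group at this same position, a 2.0-fold higher number from compound 1 to compound 3 (0.30 log units; within the scatter) and a 1.4-fold lower number from compound 2 to compound 3 (0.14 log units; within the scatter), and neither moves beyond the scatter; the third, a 2.8-fold higher number from compound 1 to compound 2 (0.45 log units; beyond the scatter), is modest. For the measured compounds named here, no measured compound carries a five-membered aromatic group here, so the step to compound 4 is less anchored.

The expectation for compound 4 in this assay is therefore a step of about a 1.1-fold higher number from compound 3 to compound 4 (0.02 log units; within the scatter), that is, no change beyond the scatter, giving an estimated 11 ug/mL within a range from 4.5 ug/mL to 28 ug/mL.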

Compound 4, half-maximal effective concentration: > 300 ug/mL
Compound 4: no number, only a limit; the forecaster's own chance of this, stated with the estimate: 10%; at least 27-fold (1.43 log units) between middle value and limit.
By their numbers in this assay, from the lowest: compounds 1, 3 and 2 (each within the scatter of the next, the first and the last beyond it). At a limit, above all of these: compound 4.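

Compound 4 gives no number in this assay, only a limit: the limit of > 300 ug/mL in this assay, at which 1 of the 4 values shown sits. The earlier compounds shown here showed at most a modest step at this position on the five-membered ring, yet each of the three changes to furan-2-yl is large (an at least 28-fold higher number from compound 3 to compound 4 (1.46 log units; beyond the scatter) and an at least 20-fold higher number from compound 2 to compound 4 (1.31 log units; beyond the scatter) and an at least 57-fold higher number from compound 1 to compound 4 (1.76 log units; beyond the scatter)). So this position does not accept every aromatic group: among the four compounds, the three with a six-membered aromatic ring of carbon only give numbers, while the one with a five-membered aromatic ring containing a hetero atom reaches the limit.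

With a single such compound, the ring size, the ring oxygen and the missing substituent on the ring cannot be told apart. The compounds shown leave open how an unsubstituted phenyl, a thiophen-2-yl or a pyridyl group would behave here.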